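Methoxy for Cyano on a Second Bicyclic Core

The source may hold more compounds than are shown below. What is called first, only, known or untested is meant among the compounds shown, and "the series" means these compounds.

Compound 1 `N#Cc1cncc(N2CC[C@@H]3CN[C@@H]3C2)c1` carries a cyano group on its aromatic ring. In a functional assay on HEK293 cells for agonist activity at Neuronal acetylcholine receptor; alpha4/beta2 (Homo sapiens), read by FLIPR (on this read-out lower numbers stand for an effect already at smaller amounts and higher numbers for an effect only at larger amounts of compound), compound 1 gives 1900 nM. Compound 2 `COc1cncc(N2CC[C@@H]3CN[C@@H]3C2)c1` differs from it by methoxy in place of cyano on an aromatic carbon, and in this assay compound 2 gives 2700 nM. The step of a 1.4-fold higher number from compound 1 to compound 2 (0.15 log units; within the scatter) is therefore small.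

Compound 3 `N#Cc1cncc(N2C[C@@H]3CCNC[C@@H]32)c1` has the same atoms as compound 1 joined differently; the difference between the two cores is not broken down here. In this assay compound 3 gives 2190 nM, a value within the scatter of both compound 1 and compound 2.

Compound 4 `COc1cncc(N2C[C@@H]3CCNC[C@@H]32)c1` has not yet been measured. It differs from compound 3 by methoxy in place of cyano on an aromatic carbon, the same change as between compound 1 and compound 2; the change appears twice in all among these compounds. For compound 4 a step of a 1.4-fold higher number from compound 3 to compound 4 (0.14 log units; within the scatter) is expected, set beside the earlier one, because the step of a 1.4-fold higher number from compound 1 to compound 2 (0.15 log units; within the scatter) stayed within the scatter on the core of compound 1. Compound 4 is thus estimated to give 3000 nM in this assay, with a likely range from 1500 nM to 6000 nM.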

Compound 4, half-maximal effective concentration: 7690 nM
For compound 4 the middle estimate is 2.6-fold (0.41 log units) below the measured one, and the stated range ends below it.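

On the second core, methoxy in place of cyano on an aromatic carbon gives in this assay a 3.5-fold higher number from compound 3 to compound 4 (0.55 log units; beyond the scatter), a modest step that lies beyond the scatter, whereas the same change on the core of compound 1 stayed within it. Even so, the two steps cannot be told apart: the same change on two cores in this assay, a 1.4-fold higher number (0.15 log units; within the scatter) from compound 1 to compound 2 and a 3.5-fold higher number (0.55 log units; beyond the scatter) from compound 3 to compound 4, 2.5-fold (0.39 log units) apart, within the scatter of two such steps. The change can therefore be said to carry over from one core to the other within what repeated measurements allow, but this does not show that the two cores respond identically, and two pairs of compounds set no rule for any further core.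

The compounds shown leave open how either core would read in this assay with another group on this aromatic carbon, such as an amine, a carboxylic acid or a longer chain like ethoxy. They also leave open how either core would read with only hydrogen or with a chlorine atom at that place.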